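This account rests on a few compounds, and the source may have more. Where it says the series, first, only, none or still open, it means among the compounds named here.

Compound 1 `CC(C)C(c1ncc[nH]1)c1ccc(-c2ccc3cccc(F)c3c2)[nH]c1=O` and compound 2 `CC(C)C(c1nnc[nH]1)c1ccc(-c2ccc3cccc(F)c3c2)[nH]c1=O` share one core and differ only in the five-membered ring carried on the saturated chain carbon bound to an aromatic carbon and a saturated chain carbon. In a physicochemical assay for solubility, measured as kinetic solubility, at pH 2 (a higher number here means a more soluble compound, a lower number a less soluble compound), compound 1 gives 31800 nM, and compound 2 gives 31800 nM; the step of no change at the digits printed from compound 1 to compound 2 (within the scatter) shows that swapping one small aromatic ring for another left the solubility where it was.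

Compound 3 `CC(C)NC(=O)CC(c1ccc(-c2ccc3cccc(F)c3c2)[nH]c1=O)C(C)C` goes further. Its change from compound 2 is (isopropylcarbamoyl)methyl in place of 4H-1,2,4-triazol-3-yl on a saturated chain carbon bound to an aromatic carbon and a saturated chain carbon. Here the ring is not swapped but removed, and an open chain with an amide takes its place. Among the measured compounds shown here, the only measured step, from compound 1 to compound 2, compares two rings of similar kind, so it bears on this change only loosely; no measured pair covers the loss of a ring for a chain. With so little to lean on, the expectation for compound 3 is a moderate fall in this assay, a 2.1-fold lower number from compound 2 to compound 3 (0.33 log units; beyond the scatter), though a result within the scatter of compound 2 would not surprise. Compound 3 is estimated at 15000 nM, with a range from 4000 nM to 40000 nM.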

Compound 3, solubility: 24200 nM
For compound 3 the middle estimate is 1.6-fold (0.21 log units) below the measured one; the range from low to high includes it.
By their numbers in this assay, from the lowest: compounds 3, 1 and 2 (each within the scatter of the next).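

In this assay, exchanging the ring for the open chain gives a 1.3-fold lower number from compound 2 to compound 3 (0.12 log units; within the scatter), and the comparison with the other ring gives a 1.3-fold lower number from compound 1 to compound 3 (0.12 log units; within the scatter). At this position, on a saturated chain carbon bound to an aromatic carbon and a saturated chain carbon, a five-membered aromatic ring can therefore give way to (isopropylcarbamoyl)methyl, a group with no ring, and the reading stays within the usual scatter, something the earlier ring-for-ring step could not show. Nothing measured here offers an explanation for this result.

Among the compounds shown here, the three compounds cover only two aromatic rings and one amide chain, so they leave open whether the same flat picture would hold for groups of a different kind at this place, such as an amine, a carboxylic acid or a longer chain without the amide. For the compounds shown here, they also leave open whether the isopropyl on the amide nitrogen matters at all, since no compound here carries a smaller group such as methyl there.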